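Cyclopropyl in place of the trifluoromethylphenyl group

This account rests on a few compounds, and the source may have more. Where it says the series, first, only, none or still open, it means among the compounds named here.

Working notes on a small set of agonists of the rat free fatty acid receptor 1, read in a functional assay on cells for agonist activity at Free fatty acid receptor 1 (Rattus norvegicus), read by FLIPR and calcium flux; on this read-out lower numbers stand for an effect already at smaller amounts and higher numbers for an effect only at larger amounts of compound. Compound 1 `CC#C[C@@H](Cc1nnn[nH]1)c1ccc(OCc2ccc3scc(-c4ccccc4C(F)(F)F)c3c2)cc1` gives 2 nM in this assay, the lowest of the two numbers at hand. Compound 2 `CC#C[C@@H](Cc1nnn[nH]1)c1ccc(OCc2ccc3sc(I)c(-c4ccccc4C)c3c2)cc1` carries an iodine on the five-membered ring and a methylphenyl group and gives 33 nM in this assay; its number stands above that of compound 1 by more than the usual scatter. For the measured compounds named here, no single-change pair among the measured compounds exists, so no measured step is available.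

Compound 3 `CC#C[C@@H](Cc1nnn[nH]1)c1ccc(OCc2ccc3scc(C4CC4)c3c2)cc1` is the next compound and has not been measured. It differs from compound 1 in one place: cyclopropyl in place of 2-(trifluoromethyl)phenyl on an aromatic carbon. The change removes the whole aromatic ring that carries the trifluoromethyl group and leaves a far smaller group on the same aromatic carbon of the core. In this assay a rise in the number is expected for compound 3, the step of a 20-fold higher number from compound 1 to compound 3 (1.30 log units; beyond the scatter) being estimated as beyond the scatter. Compound 3 is accordingly estimated at 40 nM in this assay, within a range of 8 nM to 200 nM.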

Compound 3, half-maximal effective concentration: 239 nM
For compound 3 the middle estimate is 6.0-fold (0.78 log units) below the measured one, outside the stated range (above it).
By their numbers in this assay, from the lowest: compound 1; then compound 2; then compound 3.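

In this assay, for the compounds shown here, the exchange of 2-(trifluoromethyl)phenyl for cyclopropyl, on an aromatic carbon two ring bonds from the ring sulfur, gives a 120-fold higher number from compound 1 to compound 3 (2.08 log units; beyond the scatter) and is the only step that isolates one place, which compound 1 and compound 2 alone could not do. The group on this carbon therefore weighs heavily on the read-out, with the rest of the structure held constant. With the much smaller cyclopropyl in place, compound 3 still gives 239 nM as a measured number, so the effect is reduced without being lost, though nothing at hand bears on why the step is so large.

Going by these compounds alone, the single step changes several things at once, so it does not separate the loss of the six-membered aromatic ring from the loss of the trifluoromethyl group or from the drop in heavy atoms. Unsubstituted phenyl, cyclohexyl or a longer chain such as n-butyl on the same carbon would be needed to pull these apart.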